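The source may report more compounds than this note shows. Statements on the series, on what has been measured and on what is new or still open speak of the compounds shown alone.

In an ADME assay on BJ cells (Homo sapiens) for cytotoxicity, with a stated time of 72 h (on this read-out lower numbers stand for an effect already at smaller amounts and higher numbers for an effect only at larger amounts of compound), compound 1 `O=C(Nc1cccc(-c2nc3ccccc3s2)c1)c1cc([N+](=O)[O-])ccc1Cl` is known only by a limit, > 27000 nM, so no exact value is available as a starting point. Compound 3 `O=C(Nc1cc(-c2nc3ccccc3s2)ccc1Cl)c1cc([N+](=O)[O-])ccc1Cl` is compound 1 with one structural change, (chloro in place of hydrogen on an aromatic carbon), a chloro in place of hydrogen on an aromatic carbon, ortho to a large group and para to a 1,3-benzothiazol-2-yl group. The nearest measured comparison is compound 2 `O=C(Nc1ccc(Cl)c(-c2nc3ccccc3s2)c1)c1cc([N+](=O)[O-])ccc1Cl`, which also carries a chloro in place of hydrogen on an aromatic carbon. Compound 2 likewise gives only a limit, > 25000 nM. Going by the values given here, the one measured step that bears on the change is a step that the two limits leave unreadable from compound 1 to compound 2. It offers no size to carry over, so no step beyond the scatter is expected in this assay. The expected change is a number no higher from compound 1 to compound 3 (the limit leaves the size open). For compound 3 the estimated value is 27000 nM, with an expected range from 12000 nM to 50000 nM.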

Compound 3, half-maximal effective concentration: > 25000 nM
Compound 3 was reported as a limit; the forecaster's own chance of this, stated with the estimate: 80%; the middle value does not contradict the limit.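

Compound 1 and compound 3 are each known only by a limit, so the step between them cannot be read. The compounds shown leave open where their actual values lie and whether a chloro in place of hydrogen changes them at all.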